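The source may report more compounds than this note shows. Statements on the series, on what has been measured and on what is new or still open speak of the compounds shown alone.

Measured so far in a functional assay on MIA PaCa-2 cells (Homo sapiens) for cytotoxicity, read by MTT assay, with a stated time of 72 h; on this read-out higher numbers stand for weaker inhibition and lower numbers for stronger inhibition:
compound 1 `C#CCn1cc(C(=O)NC(CC(=O)Nc2ccccc2)c2ccccc2)c(=O)c2cc(F)c(Cl)nc21` gives 6900 nM
compound 2 `C#CCn1cc(C(=O)NC(CC(=O)NC2CCCC2)c2ccccc2)c(=O)c2ccc(Cl)nc21` gives 2400 nM
compound 3 `C#CCn1cc(C(=O)NC(CC(=O)Nc2ccccn2)c2ccccc2)c(=O)c2cc(F)c(Cl)nc21` gives only a limit of the assay, > 10000 nM

Compound 1 stands highest of the two numbers, with compound 2 the nearest below it, beyond the scatter. Compound 4 `C#CCn1cc(C(=O)NC(CC(=O)NC2CCCC2)c2ccccc2)c(=O)c2cc(F)c(Cl)nc21` differs from compound 1 by cyclopentyl in place of phenyl on an amide-type nitrogen. For the measured compounds named here, the only measured step at that amide-type nitrogen, an at least 1.4-fold higher number from compound 1 to compound 3 (0.16 log units; that floor lies within the scatter), runs into the limit of > 10000 nM in this assay, at which 1 of the 3 values shown sits, and concerns pyridin-2-yl, not cyclopentyl, so it does not bear directly on compound 4. Compound 2 already carries the cyclopentylcarbamoyl group and differs from compound 4 in one other place only; its number sits below that of compound 1. For this assay the estimate for compound 4 is 3000 nM, within 1000 nM to 9000 nM, meaning an expected step of a 2.3-fold lower number from compound 1 to compound 4 (0.36 log units; beyond the scatter).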

Compound 4, half-maximal inhibitory concentration: 4400 nM
Compound 4: middle estimate off by 1.5-fold (0.17 log units), on the low side, and the stated range covers the measured number.
By their numbers in this assay, from the lowest: compounds 2, 4 and 1 (each within the scatter of the next, the first and the last beyond it). At a limit, above all of these: compound 3.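

In this assay, cyclopentyl and phenyl on the amide-type nitrogen are not separated: a 1.6-fold lower number from compound 1 to compound 4 (0.20 log units; within the scatter). Fluoro in place of hydrogen on an aromatic carbon, now seen as a single difference, is not separated either: a 1.8-fold higher number from compound 2 to compound 4 (0.26 log units; within the scatter). Cyclopentyl in place of pyridin-2-yl gives a step beyond the scatter, an at least 2.2-fold lower number from compound 3 to compound 4 (0.35 log units; beyond the scatter), but this step is only a bound, as compound 3 sits at a limit: the limit of > 10000 nM in this assay, at which 1 of the 4 values shown sits.

Open, going by these compounds, is whether a piperidin-4-yl group or a longer alkyl chain on the amide-type nitrogen would move the number beyond the scatter.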